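A few compounds are considered here, and "the series" means these few. Any claim that something is new, unique, unknown or untested is made for them only; others in the source may bear on it.

Measured in a functional assay on A549 cells (Homo sapiens) for antiproliferative activity, read by XTT assay, with a stated time of 72 h; on this read-out lower numbers stand for stronger inhibition and higher numbers for weaker inhibition:
compound 1 `COc1ccc(-c2cc3ccccc3nc2/C=C/C(=O)c2ccccc2)cc1` gives 7410 nM
compound 2 `COc1ccc(-c2cc3ccccc3nc2/C=C/C(=O)c2ccc(F)cc2)cc1` gives 8320 nM
compound 3 `COc1ccc(C(=O)/C=C/c2nc3ccccc3cc2-c2ccc(OC)cc2)cc1` gives 8500 nM

Compound 1 stands at one end of these three numbers, yet the steps of a 1.1-fold higher number from compound 1 to compound 2 (0.05 log units; within the scatter) and a 1.1-fold higher number from compound 1 to compound 3 (0.06 log units; within the scatter) both lie within the scatter, and the same holds for a 1.0-fold higher number from compound 2 to compound 3 (0.01 log units; within the scatter), so the three compounds sit together. Compound 4 `COc1ccc(-c2cc3ccccc3nc2/C=C/C(=O)c2c[nH]c3ccccc23)cc1` differs from compound 1 by 1H-indol-3-yl in place of phenyl on a carbonyl carbon. Among the compounds with values here, no measured step bears directly on this change: the three measured steps, all within the scatter, only vary a substituent on the phenyl that now leaves. With nothing pointing either way, compound 4 is expected to show a number close to that of compound 1 in this assay, and the expected step of a 1.5-fold lower number from compound 1 to compound 4 (0.17 log units; within the scatter) is accordingly small. The estimate for compound 4 is 5000 nM, with a range from 1500 nM to 17000 nM.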

Compound 4, half-maximal inhibitory concentration: > 10000 nM
Compound 4 ended at the assay's limit (the forecaster's own chance of this, stated with the estimate: 5%); middle value at least 2.0-fold (0.30 log units) from the limit.
By their numbers in this assay, from the lowest: compounds 1, 2 and 3 (each within the scatter of the next). At a limit, above all of these: compound 4.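

In this assay compound 4 sits at a limit of the assay, not at a number: > 10000 nM. Replacing the whole aryl group on the carbonyl carbon with 1H-indol-3-yl gives an at least 1.3-fold higher number from compound 1 to compound 4 (0.13 log units; that floor lies within the scatter), with an at least 1.1-fold higher number from compound 3 to compound 4 (0.07 log units; that floor lies within the scatter) and an at least 1.2-fold higher number from compound 2 to compound 4 (0.07 log units; that floor lies within the scatter). Each floor lies within the scatter, yet this first exchange of the ring itself, unlike the substituent changes on the phenyl, brought no lower number.

Going by these compounds, how far compound 4 lies past its limit stays open. So does whether a pyridin-3-yl or a phenyl bearing a carboxylic acid at this carbonyl carbon would lower the number.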